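Alkoxy in place of chloro on the fused core

The compounds below may be only part of what the source reports. "The series", "measured", "known", "first", "only" and "open" are said of these compounds alone.

The measured compounds:
compound 1 `CCCOc1ccc2oc(/C=C/[S+](C)[O-])cc(=O)c2c1` gives 1100 nM in a functional assay on A549 cells (Homo sapiens) for cytotoxicity, with a stated time of 48 h; a higher number here means a weaker inhibitor, a lower number a stronger inhibitor;
compound 2 `CCOc1ccc2oc(/C=C/[S+](C)[O-])cc(=O)c2c1` gives 1500 nM in this assay;
compound 3 `C[S+]([O-])/C=C/c1cc(=O)c2cc(Cl)ccc2o1` gives 1700 nM in this assay.

Compound 3 carries the highest of the three numbers, though its gaps to compound 2 and compound 1 are both within the scatter. Compound 4 `CC(C)COc1ccc2oc(/C=C/[S+](C)[O-])cc(=O)c2c1` differs from compound 3 by isobutoxy in place of chloro on an aromatic carbon. Going by the values given here, two measured steps bear on this: a 1.5-fold higher number from compound 1 to compound 3 (0.19 log units; within the scatter) and a 1.1-fold higher number from compound 2 to compound 3 (0.05 log units; within the scatter), both within the scatter. Read in reverse, an alkoxy group in place of chloro gave at most a small lowering. Compound 4 is therefore expected to show a step of about a 1.4-fold lower number from compound 3 to compound 4 (0.15 log units; within the scatter), in line with compound 1 at 1100 nM. The estimate for compound 4 is 1200 nM, with a range from 600 nM to 2400 nM.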

Compound 4, half-maximal inhibitory concentration: 1100 nM
The estimate for compound 4 lay 1.1-fold (0.04 log units) above the measured number, within the range that was stated.
By their numbers in this assay, from the lowest: compounds 1, 4, 2 and 3 (each within the scatter of the next).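

With isobutoxy added, this assay still gives no step beyond the scatter at this aromatic carbon: a 1.5-fold lower number from compound 3 to compound 4 (0.19 log units; within the scatter), a 1.4-fold lower number from compound 2 to compound 4 (0.13 log units; within the scatter) and no change at the digits printed from compound 1 to compound 4 (within the scatter). The added methyl on the chain of compound 1 therefore has no readable effect, and chloro, ethoxy, propoxy and isobutoxy cannot be told apart here. No measurement shown offers an explanation for these steps. On these data alone, whether an amine or a carboxylic acid on this carbon would give a step beyond the scatter remains open, as does the result for a longer chain.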